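From carboxy to hydroxymethyl on a shared core

The source may hold more compounds than are shown below. What is called first, only, known or untested is meant among the compounds shown, and "the series" means these compounds.

Compound 1 (`Cc1coc(-c2ccc3c(c2O)CCCC3)c1C(=O)O`): 50 uM
Compound 2 (`COc1c(-c2occ(C)c2C(=O)O)ccc2c1CCCC2(C)C`): 43.3 uM

Both compounds were tested in a functional assay on KB cells (Homo sapiens) for cytotoxicity, read by sulforhodamine B assay, with a stated time of 3 days (on this read-out lower numbers stand for an effect already at smaller amounts and higher numbers for an effect only at larger amounts of compound), and their numbers lie within the usual scatter of each other, so compound 2 at 43.3 uM does not stand apart from compound 1 at 50 uM in this small set.

The next compound to be tested is compound 3 (`COc1c(-c2occ(C)c2CO)ccc2c1CCCC2(C)C`). It keeps the core of compound 2 and changes one group: hydroxymethyl in place of carboxy on an aromatic carbon. Among the measured compounds shown here, no measured pair shows what this exchange does, so the expectation rests only on compound 2 at 43.3 uM and on the change itself.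

In this assay a modest step toward a lower number is expected, about at the edge of the scatter, and no real change would also be plausible. In numbers, the expected move is a 2.0-fold lower number from compound 2 to compound 3 (0.29 log units; within the scatter) on this estimate. For compound 3 the estimated value is 22 uM with an expected range from 7 uM to 60 uM once it is measured.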

Compound 3, concentration for half-maximal effect: 25.3 uM
Estimate against measurement, compound 3: 1.2-fold (0.06 log units) below; the measured number falls inside the stated range.
By their numbers in this assay, from the lowest: compounds 3, 2 and 1 (each within the scatter of the next).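

In this assay the exchange of carboxy for hydroxymethyl on this aromatic carbon of the five-membered aromatic ring with 1 oxygen gives a 1.7-fold lower number from compound 2 to compound 3 (0.23 log units; within the scatter) and is the only matched pair shown, so the two groups cannot be told apart at this place. Compound 3 thus shows that a number of this size does not depend on the carboxy group being present: hydroxymethyl has one oxygen fewer and no double bond outside aromatic rings, while each group is counted with 1 hydrogen-bond donor, 1 hydrogen-bond acceptor and no net charge. No measurement at hand accounts for the size of this step.

Going by these compounds, it remains open whether an amine, a primary amide or a longer chain in this same place would move the number beyond the scatter. On these data alone, it is equally open whether hydroxymethyl in place of carboxy would give a similar step on the core of compound 1, which carries a free hydroxy group rather than a methoxy group.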